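A few compounds are considered here, and "the series" means these few. Any claim that something is new, unique, unknown or untested is made for them only; others in the source may bear on it.

In an assay on membranes from HEK293 cells for displacement of a labelled ligand from adenosine receptor A2b (Homo sapiens), read by scintillation counting, with a stated time of 30 min, tested at 1 uM (on this read-out higher numbers stand for more inhibition at the one concentration tested (going by the name of the read-out) and lower numbers for less inhibition), compound 1, whose structure is `CC1=C(C(=O)C2CC2)C(c2ccoc2)NC(=O)N1`, gives 10%. Two close relatives share its core and differ only in the aromatic ring on a saturated ring carbon. Compound 2 `CC1=C(C(=O)C2CC2)C(c2cccs2)NC(=O)N1` gives 1% in this assay, and compound 3 `CC1=C(C(=O)C2CC2)C(c2ccsc2)NC(=O)N1` gives 1%. The move from furan-3-yl to thiophen-2-yl gives a number 9 percentage points lower from compound 1 to compound 2 (within the scatter), the move to thiophen-3-yl gives a number 9 percentage points lower from compound 1 to compound 3 (within the scatter), and between the two thiophene isomers there is no change at the digits printed from compound 2 to compound 3 (within the scatter). Compound 1 thus carries the largest of the three numbers, but every gap to the others lies within the scatter, so the three compounds cannot be told apart on these readings.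

Compound 4 `CCNC(=O)C1=C(C)NC(=O)NC1c1ccoc1` is not yet measured. It differs from compound 1 at a different place: ethylamino in place of cyclopropyl on a carbonyl carbon. Within the data shown here, no measured step touches the carbonyl carbon, so none of the three bears directly on this change; all that is known is that the core itself sits low in this assay whatever ring is attached. The expectation is therefore a step of a number 2 percentage points lower from compound 1 to compound 4 (within the scatter), that is, nothing beyond the scatter. Compound 4 is expected to give about 8%, within a range from 0% to 25%.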

Compound 4, a percentage reported as inhibition, at one concentration (the size of the read-out at that concentration, not a potency): 2%
Estimate against measurement, compound 4: 6 percentage points above, and the stated range covers the measured number.
By their numbers in this assay, from the lowest: compounds 2, 3, 4 and 1 (each within the scatter of the next).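

Putting ethylamino in place of cyclopropyl on the carbonyl carbon, which turns cyclopropylcarbonyl into ethylcarbamoyl, gives in this assay a number 8 percentage points lower from compound 1 to compound 4 (within the scatter). Among these compounds, this is the first reading at this position, and it shows that exchanging a three-membered carbon ring for an open chain carrying a hydrogen-bond donor does not separate compound 4 from compound 1 on this read-out, just as the exchanges of the aromatic ring did not separate compounds 1, 2 and 3. No measurement is available that bears on why the step has this size.

From the compounds shown here alone, a single pair at a single concentration says little about the carbonyl carbon as a whole, so it remains open whether a different group there, such as a longer chain like butylamino, a dimethylamino group or a phenyl ring, would move the number beyond the scatter. Also open, going by these compounds, is whether ethylamino would behave the same way with a thiophene ring on the saturated ring carbon, as in compound 2 or compound 3, in place of the furan-3-yl ring of compound 1.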